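Extending the Ethyl Chain to Butyl on the Aryl Ketone Acid

A few compounds are considered here, and "the series" means these few. Any claim that something is new, unique, unknown or untested is made for them only; others in the source may bear on it.

Measured compounds:
compound 1, `O=C(O)/C=C/C(=O)c1ccc(Cl)c(Cl)c1`, 28300 nM
compound 2, `CC(C)c1ccc(C(C)C)c(C(=O)/C=C/C(=O)O)c1`, 4750 nM
compound 3, `CCc1ccc(C(=O)/C=C/C(=O)O)cc1`, 27800 nM

In a functional assay on HeLa cells (Homo sapiens) for inhibition, read by MTT assay, with a stated time of 72 h (a lower number here means a stronger inhibitor, a higher number a weaker inhibitor), compound 3 gives 27800 nM, the second highest of the three numbers. Compound 1 sits within the scatter of compound 3, so no order between them can be drawn. Compound 2, which carries two isopropyl groups, gives 4750 nM, a lower number than compound 3 by a gap beyond the scatter.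

Compound 4, `CCCCc1ccc(C(=O)/C=C/C(=O)O)cc1`, differs from compound 3 by one change: ethyl in place of hydrogen on a saturated chain carbon, two bonds along the chain from an aromatic carbon. For the measured compounds named here, no measured pair shows this exact step, so its size is unknown. Given that compound 2 with its larger alkyl groups gives 4750 nM, a lowering of modest size is expected, a 1.9-fold lower number from compound 3 to compound 4 (0.27 log units; within the scatter). For compound 4 in this assay the estimate is 15000 nM, with a range from 5000 nM to 40000 nM.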

Compound 4, half-maximal inhibitory concentration: 4780 nM
Beside the measured number, compound 4's estimate is 3.1-fold (0.50 log units) above it; the whole stated range lies above it.
By their numbers in this assay, from the lowest: compounds 2 and 4 (each within the scatter of the next); then compounds 3 and 1 (each within the scatter of the next).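

In this assay, for the compounds shown here, the change from ethyl to butyl gives a 5.8-fold lower number from compound 3 to compound 4 (0.76 log units; beyond the scatter) and so shows that this saturated chain position responds to added length, the first single-place step that could be read in this set. Nothing measured here explains why the step has this size. As far as these compounds go, whether a longer chain such as hexyl would lower the number further remains open. So does whether a hydroxyl or an amine at the end of the butyl chain would keep the step.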